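A few compounds are considered here, and "the series" means these few. Any claim that something is new, unique, unknown or untested is made for them only; others in the source may bear on it.

Working notes on the series.

Of the compounds shown here, three have been measured in an assay on cells for inhibition of Palmitoleoyl-protein carboxylesterase NOTUM variant C330S (Homo sapiens), read by fluorescence, with a stated time of 40 min; a higher number here means a weaker inhibitor, a lower number a stronger inhibitor. Compound 2 `Cc1cc(C(=O)O)c(C)n1-c1ccc(Cl)c(Cl)c1` gives 270 nM. Compound 1 `Cc1cc(C(=O)O)c(C)n1-c1ccc(Cl)c(C(F)(F)F)c1` gives 2100 nM. Compound 3 `O=C(O)C1CCN(c2ccc(Cl)c(Cl)c2)C1` gives 1200 nM.

Compound 1 differs from compound 2 in one place only: trifluoromethyl in place of chloro on an aromatic carbon. That change made the step of a 7.8-fold higher number from compound 2 to compound 1 (0.89 log units; beyond the scatter). Compound 3 and compound 2 have different cores, and the difference between the two cores is not broken down here; what the two values show is that compound 3 gives the higher number of the two, and that gap lies beyond the scatter. Compound 3 and compound 1 lie within the scatter of each other, so nothing is drawn from that pair.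

Compound 4 `O=C(O)C1CCN(c2ccc(C(F)(F)F)c(Cl)c2)C1` has not yet been measured in this assay. It differs from compound 3 by trifluoromethyl in place of chloro on an aromatic carbon. This is the same kind of change as that from compound 2 to compound 1, but the surroundings are not identical: in compound 1 the entering trifluoromethyl is meta to a large group, whereas in compound 4 it is para to a group of 8 heavy atoms. The one measured instance of the change weakened inhibition, and with nothing in the shown compounds pointing the other way, a step of similar direction is expected for compound 4, estimated as a 5.8-fold higher number from compound 3 to compound 4 (0.77 log units; beyond the scatter), resting on the step of a 7.8-fold higher number from compound 2 to compound 1 (0.89 log units; beyond the scatter). The different position and the different core leave room for the size to differ, so the expected range is kept wide. Compound 4 is accordingly estimated at 7000 nM in this assay, expected to fall between 2500 nM and 20000 nM.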

Compound 4, half-maximal inhibitory concentration: 8500 nM
Estimate against measurement, compound 4: 1.2-fold (0.08 log units) below, within the range that was stated.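

Trifluoromethyl in place of chloro again weakens inhibition in this assay, with a 7.1-fold higher number from compound 3 to compound 4 (0.85 log units; beyond the scatter). Set beside the earlier instance, the size of the step carries over between the two cores, with no difference beyond the scatter: the same change on two cores in this assay, a 7.8-fold higher number (0.89 log units; beyond the scatter) from compound 2 to compound 1 and a 7.1-fold higher number (0.85 log units; beyond the scatter) from compound 3 to compound 4, 1.1-fold (0.04 log units) apart, within the scatter of two such steps This shows that the change travelled with much the same size across these two cores in this assay, but with only two cores and a single pair of groups it does not show that the step would hold on any further core, nor does it explain why the two steps agree.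

The compounds shown carry only chloro or trifluoromethyl at the changed place, so it stays open whether a nitrile, a methyl or a methoxy there would give matching steps on both cores. All four compounds also keep the carboxylic acid, which leaves open what an amide or a tetrazole in its place would do on either core, and whether the trifluoromethyl step would survive such an exchange.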